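Carbamate Series: Trifluoromethyl for Fluoro on the Aryl Ring

A few compounds are considered here, and "the series" means these few. Any claim that something is new, unique, unknown or untested is made for them only; others in the source may bear on it.

Measured so far:
compound 1, `CC(C)=CCC1Cc2c(OCc3ccccc3)cc(=O)n(CCCO)c2CC1(C)C`: 11.1%
compound 2, `CC(C)=CCC1Cc2c(OC(=O)Nc3cccc(F)c3)cc(=O)n(CCCO)c2CC1(C)C`: 0%

Of the compounds shown here, two sharing the same core have been measured in a functional assay on PANC-1 cells (Homo sapiens) for inhibition, read by MTT assay, with a stated time of 24 h, tested at 10 uM; on this read-out higher numbers stand for more inhibition at the one concentration tested (going by the name of the read-out) and lower numbers for less inhibition. In this assay compound 1 gives 11.1%, and compound 2 gives 0%. Among the measured compounds shown here, the single step between them, a number 11.1 percentage points lower from compound 1 to compound 2 (beyond the scatter), places compound 2 as the lower of the two numbers, with compound 1 as its nearest neighbour.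

Compound 3, `CC(C)=CCC1Cc2c(OC(=O)Nc3cccc(C(F)(F)F)c3)cc(=O)n(CCCO)c2CC1(C)C`, has not yet been measured. Compared with compound 2 it carries a change (trifluoromethyl in place of fluoro on an aromatic carbon), the ring otherwise unchanged. For the measured compounds named here, no measured step concerns a substituent on this aryl ring: the only step recorded, from compound 1 to compound 2, exchanges the whole group on the ring oxygen and therefore says nothing direct about swapping fluoro for trifluoromethyl. With compound 2 already at the bottom of the scale, the expectation for compound 3 is a step no larger than the scatter, a number 5 percentage points higher from compound 2 to compound 3 (within the scatter). Compound 3 is therefore estimated at 5%, within a range from 0% to 20%.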

Compound 3, a percentage reported as inhibition, at one concentration (the size of the read-out at that concentration, not a potency): 0%
Beside the measured number, compound 3's estimate is 5 percentage points above it; the measured number falls inside the stated range.
By their numbers in this assay, from the lowest: compounds 2 and 3 (each within the scatter of the next); then compound 1.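

In this assay, among the compounds shown here, the exchange on the aryl ring of the carbamate gives no change at the digits printed from compound 2 to compound 3 (within the scatter), the first reading of any substituent on this ring, here on an aromatic carbon and meta to a large group. Enlarging the group from fluoro to trifluoromethyl does not lift the read-out, since compound 3 prints the same number as compound 2, 0%, but a number of this size could not show a further loss of inhibition, so the step shows only that this change restores none. No measured property of these compounds bears on why the two carbamates read alike.

On these data alone, it remains open whether any group at this aromatic carbon can raise the number, for instance an amine, a carboxylic acid or a methoxy group in place of trifluoromethyl. As far as these compounds go, it is equally open whether the carbamate itself holds the number down, which a comparison of compound 1 with a carbamate bearing a longer alkyl chain instead of the aryl ring would not settle alone.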